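Amide-bearing oxazole series: indole to azaindazole swap

A few compounds are considered here, and "the series" means these few. Any claim that something is new, unique, unknown or untested is made for them only; others in the source may bear on it.

Measured so far in a functional assay on HEK293 cells for positive allosteric modulation of metabotropic glutamate receptor 5 (Homo sapiens), read by calcium flux; on this read-out higher numbers stand for larger maximal responses and lower numbers for smaller maximal responses:
- compound 1 `O=C(c1ccc(F)cc1)N1CCc2nc(COc3ccc(F)c(F)c3)oc2C1` gives 40%
- compound 2 `O=C(c1c[nH]c2ccccc12)N1CCc2nc(COc3ccccc3)oc2C1` gives 71%
- compound 3 `Cn1cc(C(=O)N2CCc3nc(COc4ccccc4)oc3C2)c2ccccc21` gives 70%

Compound 2 carries the highest of the three numbers, but compound 3 lies so close that the two cannot be ordered; only compound 1, which differs from compound 2 in more than one place, sits clearly lower. Going by the values given here, the single one-place step so far, a number 1 percentage points lower from compound 2 to compound 3 (within the scatter), concerns the aromatic nitrogen of the indole and is within the scatter, so the series has so far tolerated a change on that part of the amide substituent without a shift in this assay.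

Compound 4 `O=C(c1n[nH]c2ccncc12)N1CCc2nc(COc3ccccc3)oc2C1` is not yet measured. It differs from compound 2 as follows: a group of 9 heavy atoms (6 carbon, 3 nitrogen; one five-membered aromatic ring with 2 hetero atoms, one six-membered aromatic ring with 1 hetero atom) in place of a group of 9 heavy atoms (8 carbon, 1 nitrogen; one five-membered aromatic ring with 1 hetero atom, one six-membered aromatic ring of carbon only), on a carbonyl carbon

Among the compounds with values here, no measured step shows an exchange of ring atoms in the bicyclic amide substituent, so the step from compound 2 cannot be sized from the data; the only related evidence, a number 1 percentage points lower from compound 2 to compound 3 (within the scatter), shows that the aromatic nitrogen itself is not critical. A modest decrease is expected, with a wide range. For compound 4 the expected step is a number 16 percentage points lower from compound 2 to compound 4 (beyond the scatter). Compound 4 is therefore estimated at 55%, with a range from 30% to 80%.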

Compound 4, largest response reached (reported as percent of maximum), in percent of the reference or control that the assay uses: 53%
Compound 4: the middle estimate sits 2 percentage points above what was measured; low and high end bracket the measured number.
By their numbers in this assay, from the lowest: compound 1; then compound 4; then compounds 3 and 2 (each within the scatter of the next).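

In this assay, going by these compounds alone, exchanging 1H-indol-3-yl on the carbonyl carbon for the group with a five-membered aromatic ring with 2 hetero atoms and a six-membered aromatic ring with 1 hetero atom gives a number 18 percentage points lower from compound 2 to compound 4 (beyond the scatter), the first one-place step beyond the scatter. Methyl on the aromatic nitrogen, by contrast, gave a number 1 percentage points lower from compound 2 to compound 3 (within the scatter), so this amide substituent tolerates that change but not the exchange of ring atoms without a loss of maximal response, although the loss is modest and compound 4 keeps a clear response at 53%. No measurement on hand accounts for this loss.

The compounds shown leave open which of the exchanged ring atoms carries the step; a 1H-indazol-3-yl group on the same carbonyl carbon, with only the five-membered ring changed, would separate the contributions of the two rings. Also open, on these data alone, is whether methyl on the aromatic nitrogen of the entering group would remain within the scatter, as it does on the indole of compound 2.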